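Widening the amine ring: from compound 2 to compound 3

The source may report more compounds than this note shows. Statements on the series, on what has been measured and on what is new or still open speak of the compounds shown alone.

Measured compounds:
compound 1 `Cc1ccc(S(=O)(=O)Nc2ccc(-c3ccccc3N(C)C)nn2)cc1`: 4.5 nM
compound 2 `Cc1ccc(S(=O)(=O)Nc2ccc(-c3ccccc3N3CCCC3)nn2)cc1`: 1.7 nM

In an assay on mitochondria from liver for inhibition of kynurenine 3-monooxygenase (Mus musculus), read by LC-MS, with stated times of 5 min and 30 min (a higher number here means a weaker inhibitor, a lower number a stronger inhibitor), compound 1 gives 4.5 nM and compound 2 gives 1.7 nM. Within the data shown here, the only measured step is a 2.6-fold lower number from compound 1 to compound 2 (0.42 log units; beyond the scatter), which leaves compound 2 with the lower of the two numbers.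

Compound 3 `Cc1ccc(S(=O)(=O)Nc2ccc(-c3ccccc3N3CCCCC3)nn2)cc1` differs from compound 2 by piperidin-1-yl in place of pyrrolidin-1-yl on an aromatic carbon. Among the measured compounds shown here, the one step that bears on this change is a 2.6-fold lower number from compound 1 to compound 2 (0.42 log units; beyond the scatter), where a larger group also entered on the same aromatic carbon; that step was modest, and the further enlargement from a five-membered to a six-membered ring is smaller in kind than the earlier one. Compound 3 is therefore expected to show no step beyond the scatter, a 1.1-fold lower number from compound 2 to compound 3 (0.05 log units; within the scatter), in this assay. The estimate for compound 3 is 1.5 nM, with a range from 0.5 nM to 5 nM.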

Compound 3, half-maximal inhibitory concentration: 2.4 nM
Beside the measured number, compound 3's estimate is 1.6-fold (0.20 log units) below it; the measured number falls inside the stated range.
By their numbers in this assay, from the lowest: compounds 2, 3 and 1 (each within the scatter of the next, the first and the last beyond it).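

In this assay, a six-membered ring on this aromatic carbon, ortho to a large group, reads much like the five-membered one: piperidin-1-yl in place of pyrrolidin-1-yl gives a 1.4-fold higher number from compound 2 to compound 3 (0.15 log units; within the scatter) and so leaves the two rings unseparated. Compound 3 also stands apart from compound 1 less clearly than compound 2 does, with a 1.9-fold lower number from compound 1 to compound 3 (0.27 log units; within the scatter) as its step, so the gain over dimethylamino that was beyond the scatter for pyrrolidin-1-yl is not matched by piperidin-1-yl. No measurement shown here offers an explanation for these numbers.

The compounds shown leave open whether a still larger ring such as azepane would stay in this range. They also leave open what an added ring oxygen, as in morpholine, or an open-chain diethylamino group would do on this carbon.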